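Toward compound 3: a step from two limits

This account rests on a few compounds, and the source may have more. Where it says the series, first, only, none or still open, it means among the compounds named here.

In an ADME assay on MT4 cells (Homo sapiens) for cytotoxicity, read by MTT assay, with a stated time of 4 days (a lower number here means that less compound is tolerated, a higher number that more compound is tolerated), compound 1 (`Cc1ccc(OCCn2ccc(=O)n(Cc3cc(C)ccc3C)c2=O)cc1`) gives > 343000 nM, which is a limit of the assay and not a number. Compound 2 (`Cc1ccc(OCCn2ccc(=O)n(Cc3cc(C)cc(C)c3)c2=O)cc1`) gives > 343000 nM, which is also a limit. Compound 2 therefore has no number of its own and stands at the limit of > 343000 nM in this assay, at which 2 of the 2 values shown sit. Compound 3 (`Cc1ccc(OCCn2ccc(=O)n(Cc3c(C)cc(C)cc3C)c2=O)cc1`) follows from compound 2 by one change: 2,4,6-trimethylphenyl in place of 3,5-dimethylphenyl on a saturated chain carbon bound to an aromatic nitrogen. Among the measured compounds shown here, the only measured step that bears on this change is a step that the two limits leave unreadable from compound 1 to compound 2, so it offers no size to carry over. With neither measured compound giving a number in this assay, no step beyond the scatter is expected. The estimated change is an at least 1.1-fold lower number from compound 2 to compound 3 (0.05 log units; that floor lies within the scatter). Compound 3 is expected at 300000 nM, with an estimated range from 100000 nM to 400000 nM, and it may well be reported only as a limit.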

Compound 3, half-maximal cytotoxic concentration: 133000 nM
Beside the measured number, compound 3's estimate is 2.3-fold (0.35 log units) above it; the range from low to high includes it.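

In this assay, among the compounds shown here, compound 3 is the first compound here with a number of its own, 133000 nM, so a change on a saturated chain carbon bound to an aromatic nitrogen can now be read. The 2,4,6-trimethylphenyl group gives an at least 2.5-fold lower number from compound 2 to compound 3 (0.41 log units; beyond the scatter), and against the 2,5-dimethylphenyl group it gives an at least 2.5-fold lower number from compound 1 to compound 3 (0.41 log units; beyond the scatter), so this position can move the tolerated concentration beyond the scatter. The two dimethylphenyl compounds had shown only the limit, and it remains a limit and not a number: the limit of > 343000 nM in this assay, at which 2 of the 3 values shown sit.

Both steps are floors, so their full size stays open, and the compounds shown do not separate the added methyl group from the changed pattern of methyl groups. On these data alone, how a ring bearing an amine or a carboxylic acid would fare at this place also stays open.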